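The compounds below may be only part of what the source reports. "The series", "measured", "known", "first", "only" and "open" are said of these compounds alone.

Compounds measured so far:
- compound 1, `NC(=O)c1cn(Cc2nnc(-c3cc(S(N)(=O)=O)c(SCc4ccccc4)cc3Cl)o2)nn1`: 72000 nM
- compound 2, `NCc1nnc(-c2cc(S(N)(=O)=O)c(SCc3ccccc3)cc2Cl)o1`: 120000 nM
- compound 3, `NS(=O)(=O)c1cc(-c2nnc(CNS(=O)(=O)c3ccc(Cl)cc3)o2)c(Cl)cc1SCc1ccccc1`: 32000 nM

These three share one core and differ only in the group carried on the carbon attached to the five-membered ring. In a functional assay on HCT-116 cells (Homo sapiens) for cytotoxicity, read by MTT assay, with a stated time of 72 h (on this read-out higher numbers stand for weaker inhibition and lower numbers for stronger inhibition), compound 3 gives the lowest number of the three. Its nearest neighbour is compound 1, with the step of a 2.3-fold lower number from compound 1 to compound 3 (0.35 log units; beyond the scatter); its furthest is compound 2, with the step of a 3.8-fold lower number from compound 2 to compound 3 (0.57 log units; beyond the scatter). The remaining step, a 1.7-fold higher number from compound 1 to compound 2 (0.22 log units; within the scatter), lies within the scatter.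

Compound 4, `NS(=O)(=O)c1cc(-c2nnc(/C=C/c3ccccc3)o2)c(Cl)cc1SCc1ccccc1`, is the next compound to be tested in this assay. The change from compound 3 is 2-phenylethenyl in place of (((4-chlorophenyl)sulfonyl)amino)methyl on an aromatic carbon. For the measured compounds named here, none of the measured steps replaces this side group with a 2-phenylethenyl group, so no step bears directly on the change. What the measured steps do show is that varying the group at this position has so far moved the read-out only modestly, by the amounts shown for compound 1 and compound 2 relative to compound 3. On that basis the step from compound 3 to compound 4 is expected to be small, a 1.3-fold higher number from compound 3 to compound 4 (0.10 log units; within the scatter), with no confident direction. Compound 4 is therefore estimated at 40000 nM, within a range from 12000 nM to 130000 nM.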

Compound 4, half-maximal inhibitory concentration: 18000 nM
Compound 4: middle estimate off by 2.2-fold (0.35 log units), on the high side; the range from low to high includes it.
By their numbers in this assay, from the lowest: compounds 4 and 3 (each within the scatter of the next); then compounds 1 and 2 (each within the scatter of the next).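

In this assay, the 2-phenylethenyl group, built only of carbon and with no hydrogen-bond donors or acceptors, replaces the (((4-chlorophenyl)sulfonyl)amino)methyl group with no change beyond the scatter, at a 1.8-fold lower number from compound 3 to compound 4 (0.25 log units; within the scatter), so the sulfonyl and amine nitrogen of compound 3 are not required for a number in this range. Measured against the other two side groups, the same group gives the widest steps seen so far at this aromatic carbon, with a 6.7-fold lower number from compound 2 to compound 4 (0.82 log units; beyond the scatter) in place of aminomethyl and a 4.0-fold lower number from compound 1 to compound 4 (0.60 log units; beyond the scatter) in place of (4-carbamoyl-1H-1,2,3-triazol-1-yl)methyl, and among these four compounds the two side groups with a six-membered aromatic ring of carbon only give the two lowest numbers, with no compound going against this. Nothing available here accounts for these differences.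

What the compounds shown leave open is whether that carbon ring is enough by itself, as a 2-phenylethyl group or a phenyl group set directly on the five-membered ring would test the role of the double bond. They also leave open whether a chlorine on the phenyl ring of the 2-phenylethenyl group, or a longer chain before that ring, would move the number.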